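Kinetic solubility notes: compound 4 from compound 3

The source may report more compounds than this note shows. Statements on the series, on what has been measured and on what is new or still open speak of the compounds shown alone.

Measured so far:
- compound 1 `CC(=O)Nc1cc(-c2cnc(N(C)C(=O)c3c(F)cccc3Cl)c(N3CC4CC4C3)c2)n(C(C)C)n1`: 48 ug/mL
- compound 2 `CC(=O)Nc1cc(-c2ccc(N(C)C(=O)c3c(F)cccc3Cl)c(N3CCCCC3)c2)n(C(C)C)n1`: 1.3 ug/mL
- compound 3 `CC(=O)Nc1cc(-c2ccc(N(C)C(=O)c3c(F)cccc3Cl)c(N3CC4CC4C3)c2)n(C2CCC2)n1`: 0.5 ug/mL

In a physicochemical assay for solubility, measured as kinetic solubility (a higher number here means a more soluble compound, a lower number a less soluble compound), compound 1 gives 48 ug/mL, compound 2 gives 1.3 ug/mL and compound 3 gives 0.5 ug/mL. Compound 3 stands lowest of the three; the nearest number is that of compound 2, and the gap between them lies beyond the scatter, as does the much wider gap to compound 1. No pair among these three differs in one place only, so none of these gaps can be read as a single step.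

Compound 4 `CC(=O)Nc1cc(-c2ccc(N(C)C(=O)c3c(F)cccc3Cl)c(N3CC4CC4C3)c2)n(C(C)C2CC2)n1` is the next compound for this assay. It differs from compound 3 in one place: 1-cyclopropylethyl in place of cyclobutyl on an aromatic nitrogen. Among the compounds with values here, both groups are small saturated carbon groups without donors or acceptors and without charge, and no measured pair here isolates such a swap, so there is no measured step to lean on. The expectation is a step from compound 3 to compound 4 of no change at the digits printed from compound 3 to compound 4 (within the scatter), that is, nothing clearly beyond the scatter, with the number staying near the low end of the series. Compound 4 is therefore estimated at 0.5 ug/mL, with a range from 0.15 ug/mL to 1.5 ug/mL.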

Compound 4, solubility: 0.5 ug/mL
Compound 4: the middle estimate sits on the measured number at the digits printed; measured number inside the range.
By their numbers in this assay, from the lowest: compounds 3 and 4 (each within the scatter of the next); then compound 2; then compound 1.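

In this assay, within the data shown here, the change from cyclobutyl to 1-cyclopropylethyl on the aromatic nitrogen gives no change at the digits printed from compound 3 to compound 4 (within the scatter) and this is the first step that can be read at a single place. At this position, going from 4 to 5 heavy atoms and from a four-membered to a three-membered carbon ring produces no step beyond the scatter, although this reading covers only these two saturated carbon groups, neither of which has a hydrogen-bond donor, a hydrogen-bond acceptor or a net charge. The data shown offer no measured explanation for why the number holds across this change.

Still open, on these data alone, is whether a group of a different kind on this nitrogen, such as a hydroxyethyl chain, an amine or a carboxylic acid, would move the number beyond the scatter. The gaps to compound 1 and compound 2 also remain unassigned, since each of those compounds differs from compound 3 and compound 4 in more than one place, and those differences cannot be read as single steps.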